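Cinnamate and benzoate esters on a shared enone core

The source may report more compounds than this note shows. Statements on the series, on what has been measured and on what is new or still open speak of the compounds shown alone.

Measured compounds:
compound 1, `Cc1ccc(/C=C/C(=O)Oc2ccc(/C=C3\CCCCC3=O)cc2)cc1`: 202000 nM
compound 2, `COc1ccc(/C=C/C(=O)Oc2ccc(/C=C3\CCCCC3=O)cc2)cc1`: 10200 nM
compound 3, `Cc1ccc(C(=O)Oc2ccc(/C=C3\CCCCC3=O)cc2)cc1`: 44800 nM

The three measured compounds share the enone-bearing core and differ in the ester part. In a functional assay on L1210 cells (Mus musculus) (a lower number here means a stronger inhibitor, a higher number a weaker inhibitor), compound 1 gives 202000 nM and compound 2 gives 10200 nM. The change between them is methoxy in place of methyl on an aromatic carbon; the step is a 20-fold lower number from compound 1 to compound 2 (1.30 log units; beyond the scatter). Compound 3 gives 44800 nM in this assay, standing between the other two; how the core of compound 3 differs from that of compound 1 is not broken down here, so only the values themselves are compared.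

Compound 4, `COc1ccc(C(=O)Oc2ccc(/C=C3\CCCCC3=O)cc2)cc1`, has not yet been measured in this assay. It differs from compound 3 by methoxy in place of methyl on an aromatic carbon, the same change at the same place as that from compound 1 to compound 2. The expectation for compound 4 rests on compound 3 at 44800 nM and on the earlier step of a 20-fold lower number from compound 1 to compound 2 (1.30 log units; beyond the scatter); a lower number is expected, with the step estimated as a 9.0-fold lower number from compound 3 to compound 4 (0.95 log units; beyond the scatter), kept somewhat smaller than the earlier one since it is seen only once. The estimate for compound 4 is 5000 nM, between 1200 nM and 18000 nM.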

Compound 4, half-maximal inhibitory concentration: 43400 nM
For compound 4 the middle estimate is 8.7-fold (0.94 log units) below the measured one, and the stated range ends below it.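

In this assay, the change of methyl to methoxy on an aromatic carbon does not carry over from one core to the other, and the two steps differ: the same change on two cores in this assay, a 20-fold lower number (1.30 log units; beyond the scatter) from compound 1 to compound 2 and a 1.0-fold lower number (0.01 log units; within the scatter) from compound 3 to compound 4, 19-fold (1.28 log units) apart, beyond the scatter of two such steps. On the core of compound 3 the step reads a 1.0-fold lower number from compound 3 to compound 4 (0.01 log units; within the scatter), so the change from 4-methylphenyl to 4-methoxyphenyl gives no readable difference there, and the large step seen on the core of compound 1 cannot be used as a transfer rule in this series. These two pairs show that the size of the step depends on the core for these four compounds only; they do not show which feature of the ester part decides this, or what the step would be on any further core.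

As far as these compounds go, it remains open whether an amine, a carboxylic acid or a longer chain such as ethoxy on the same aromatic carbon would also separate the two cores. Also open, from the compounds shown here alone, is whether a hydroxyl or chlorine there would behave like methoxy on either core.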